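Compound 2 to compound 4: a series held at its limit

The source may report more compounds than this note shows. Statements on the series, on what has been measured and on what is new or still open speak of the compounds shown alone.

Measured in an ADME assay on HOS cells (Homo sapiens) for cytotoxicity; on this read-out lower numbers stand for higher toxicity in this test and higher numbers for lower toxicity in this test:
- compound 1 `CN(Cc1nc2ccccc2n1CCCNC(=N)N)C1CCCc2cccnc21`: > 20000 nM
- compound 2 `CN(Cc1nc2cccc(CN)c2[nH]1)C1CCCc2cccnc21`: > 20000 nM
- compound 3 `CN(Cc1nc2cccc(N3CCNCC3)c2[nH]1)C1CCCc2cccnc21`: > 20000 nM

None of these three entries is a number. Compound 2 gives > 20000 nM, and this is a limit of the assay. Compound 1 stands with > 20000 nM, again a limit. Taken together, the series shows (the limit of > 20000 nM in this assay, at which 3 of the 3 values shown sit).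

Compound 4 `CN1CCN(c2cccc3nc(CN(C)C4CCCc5cccnc54)[nH]c23)CC1` carries 4-methylpiperazin-1-yl in place of aminomethyl on an aromatic carbon, on the shared core of compound 2: 4-methylpiperazin-1-yl in place of aminomethyl on an aromatic carbon. One measured change bears directly on this, namely a step that the two limits leave unreadable from compound 2 to compound 3, with piperazin-1-yl entering in the same place. That step has no readable size, so it offers no number to carry over. Compound 3 gives > 20000 nM, which is also a limit.

With both compound 2 and compound 3 resting on that same limit, no step beyond the usual scatter is expected in this assay, and no direction can be read. A further limit is the most likely report. The step expected is a step that the limit leaves unreadable from compound 2 to compound 4. The estimated value for compound 4 is 25000 nM, with an expected range from 12000 nM to 50000 nM.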

Compound 4, half-maximal cytotoxic concentration: 14000 nM
Estimate against measurement, compound 4: 1.8-fold (0.25 log units) above; measured number inside the range.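

In this assay, among these compounds, compound 4 gives 14000 nM, the first actual number and the first sign that a group on this aromatic carbon can bring a reading inside the range of the test. The other entries stay at one shared limit of the assay: the limit of > 20000 nM in this assay, at which 3 of the 4 values shown sit.

Against that limit, placing 4-methylpiperazin-1-yl where aminomethyl stood gives an at least 1.4-fold lower number from compound 2 to compound 4 (0.15 log units; that floor lies within the scatter), and methyl in place of hydrogen on an amine nitrogen in a ring gives an at least 1.4-fold lower number from compound 3 to compound 4 (0.15 log units; that floor lies within the scatter); each figure is only a floor, and the true size of either step may be larger, so neither change is yet shown to exceed the usual variation between repeats.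

The compounds shown leave open how large these two steps really are, since only one side of each carries a number. They also leave open whether a morpholine at this place, or an ethyl group or a longer chain on the same ring nitrogen, would give a number in this assay or would return to the limit.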